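The source may report more compounds than this note shows. Statements on the series, on what has been measured and on what is new or still open speak of the compounds shown alone.

Working notes on a series of urea-linked analogues sharing one core. Compound 1 `O=C(Nc1cccc(-n2cc(-c3ccncc3)c(-c3cc(O)cc(Cl)c3)n2)c1)Nc1ccc(Cl)c(C(F)(F)F)c1` gives 100% in a functional assay on SN12C cells (Homo sapiens) for inhibition, read by sulforhodamine B assay, with a stated time of 48 h, tested at 0.1 uM; a higher number here means a weaker effect of the compound at the concentration tested, a lower number a stronger effect. Compound 2 `O=C(Nc1cccc(-n2cc(-c3ccncc3)c(-c3cc(O)cc(Cl)c3)n2)c1)Nc1ccc(Cl)c(Cl)c1` gives 95% in this assay, and the step of a number 5 percentage points lower from compound 1 to compound 2 (within the scatter) shows that exchanging one substituent on the urea-bearing aromatic ring leaves the read-out essentially unchanged. Compound 3 `COc1cc(Cl)cc(-c2nn(-c3cccc(NC(=O)Nc4cc(C(F)(F)F)cc(C(F)(F)F)c4)c3)cc2-c2ccncc2)c1` gives 97% in this assay; it sits alongside compound 1 and compound 2, differing from each by less than the usual scatter, so all three are indistinguishable at this concentration.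

Compound 4 `COc1cc(Cl)cc(-c2nn(-c3cccc(NC(=O)Nc4cccc(C(F)(F)F)c4)c3)cc2-c2ccncc2)c1` has not yet been measured in this assay. It differs from compound 3 in one place: hydrogen in place of trifluoromethyl on an aromatic carbon. For the measured compounds named here, the only measured step on the same aromatic ring, a number 5 percentage points lower from compound 1 to compound 2 (within the scatter), was within the scatter, and no measured pair removes a trifluoromethyl outright, so the data give no basis for a step beyond the scatter. The step of no change at the digits printed from compound 3 to compound 4 (within the scatter) is therefore expected to be flat. Compound 4 is estimated at 97%, with a range from 85% to 100%, in this assay.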

Compound 4, a percentage reported as activity, at one concentration (the size of the read-out at that concentration, not a potency): 96%
For compound 4 the middle estimate is 1 percentage points above the measured one; measured number inside the range.
By their numbers in this assay, from the lowest: compounds 2, 4, 3 and 1 (each within the scatter of the next).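

In this assay the replacement of trifluoromethyl by hydrogen gives a number 1 percentage points lower from compound 3 to compound 4 (within the scatter), the only measured case here in which a trifluoromethyl leaves outright rather than being exchanged for another substituent. At this carbon, meta to a trifluoromethyl group, the loss of the group therefore produces no visible shift at the single concentration tested, so a second trifluoromethyl on this ring is not required to hold the read-out where it stands. No measured evidence accounts for this flat result.

On these data alone, it remains open whether an amine or a carboxylic acid at this carbon would move the read-out beyond the scatter. As far as these compounds go, it also remains open whether removing the remaining trifluoromethyl of compound 4 would leave the read-out equally flat.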